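Swapping the Aryl Group for Pyrimidinyl on a Shared Core

The compounds below may be only part of what the source reports. "The series", "measured", "known", "first", "only" and "open" are said of these compounds alone.

Three compounds built on one shared core differ only in the group on an amine nitrogen in a ring. In a functional assay on MCF7 cells (Homo sapiens) for antiproliferative activity, read by MTT assay, with a stated time of 72 h (on this read-out lower numbers stand for stronger inhibition and higher numbers for weaker inhibition), compound 1 `Nc1nc(N)c2cc(CSC(=S)N3CCN(c4ccc(O)cc4)CC3)ccc2n1` gives 5090 nM, compound 2 `Cc1ccc(N2CCN(C(=S)SCc3ccc4nc(N)nc(N)c4c3)CC2)c(C)c1` gives 3120 nM, and compound 3 `Nc1nc(N)c2cc(CSC(=S)N3CCN(c4ccccc4Cl)CC3)ccc2n1` gives 3190 nM. Compound 2 sits at the low end of these three numbers, yet every step to the others stays within the scatter: a 1.6-fold lower number from compound 1 to compound 2 (0.21 log units; within the scatter), a 1.0-fold higher number from compound 2 to compound 3 (0.01 log units; within the scatter) and a 1.6-fold lower number from compound 1 to compound 3 (0.20 log units; within the scatter). Compound 4 `Nc1nc(N)c2cc(CSC(=S)N3CCN(c4ncccn4)CC3)ccc2n1` carries the change (pyrimidin-2-yl in place of 2,4-dimethylphenyl on an amine nitrogen in a ring). Within the data shown here, no measured step replaces one six-membered aromatic ring of carbon only by one six-membered aromatic ring with 2 hetero atoms, so the three small steps are only loose guides; they point to no shift beyond the scatter, and the expected step is a 1.3-fold higher number from compound 2 to compound 4 (0.11 log units; within the scatter). Compound 4 is therefore estimated at 4000 nM, within 1500 nM to 12000 nM.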

Compound 4, half-maximal inhibitory concentration: 4190 nM
Beside the measured number, compound 4's estimate is 1.0-fold (0.02 log units) below it; the measured number falls inside the stated range.
By their numbers in this assay, from the lowest: compounds 2, 3, 4 and 1 (each within the scatter of the next).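

Replacing a carbon-only aromatic ring with pyrimidin-2-yl, a ring with 2 hetero atoms and 2 hydrogen-bond acceptors, on this amine nitrogen causes no shift beyond the scatter in this assay (a 1.3-fold higher number from compound 2 to compound 4 (0.13 log units; within the scatter); a 1.3-fold higher number from compound 3 to compound 4 (0.12 log units; within the scatter); a 1.2-fold lower number from compound 1 to compound 4 (0.08 log units; within the scatter)). All four groups at this position therefore give numbers within the scatter of one another. Nothing available explains this result. Still open, as far as these compounds go, is whether a longer chain or a carboxylic acid on this nitrogen would move the number beyond the scatter.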